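A few compounds are considered here, and "the series" means these few. Any claim that something is new, unique, unknown or untested is made for them only; others in the source may bear on it.

Measured so far in a physicochemical assay for acid dissociation:
- compound 1 `CC(C)CN1C(=O)CN(Cc2ccc(-c3ccc(F)c(CN4CCCC(C)C4)n3)cc2)C1=O`: 8.4
- compound 2 `CC(C)CN1C(=O)CN(Cc2ccc(-c3ccc(F)c(CN4CCCCC4)n3)cc2)C1=O`: 8.6
- compound 3 `O=C1CN(Cc2ccc(-c3cccc(CN4CCCCC4)n3)cc2)C(=O)N1C1CC1`: 9

Compound 2, at 8.6, cannot be told apart from compound 1, at 8.4, since the two lie within the scatter of each other. Compound 3, at 9, is higher than compound 2, and that gap lies beyond the scatter.

Compound 4 `O=C1CN(Cc2ccc(-c3ccc(F)c(CN4CCCCC4)n3)cc2)C(=O)N1CC1CCC1` carries cyclobutyl in place of isopropyl on a saturated chain carbon bound to an amide-type nitrogen in a ring.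

Going by the values given here, no measured step changes this group on its own. Compound 3 differs from compound 2 in more than one place, so its gap cannot isolate this change. Among the compounds with values here, the only measured step, a number 0.20 log units higher from compound 1 to compound 2 (within the scatter), is hydrogen in place of methyl on a saturated ring carbon, a different place, and it stays within the scatter. With so little evidence, no shift beyond the scatter is expected in this assay. The expected step is no change at the digits printed from compound 2 to compound 4 (within the scatter). The estimate for compound 4 is 8.6, with an expected range from 8.3 to 8.9.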

Compound 4, acid dissociation constant: 8.6
Compound 4: the middle estimate sits on the measured number at the digits printed; the measured number falls inside the stated range.
By their numbers in this assay, from the lowest: compounds 1, 2 and 4 (each within the scatter of the next); then compound 3.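

In this assay putting cyclobutyl in place of isopropyl, on a saturated chain carbon bound to an amide-type nitrogen in a ring, gives no change at the digits printed from compound 2 to compound 4 (within the scatter) for this pair. This is the first step shown that changes this position on its own, and it shows that going from isobutyl to cyclobutylmethyl, with 4 carbons and a four-membered ring in place of 3 carbons and no ring, leaves the number within the scatter. Nothing available gives a reason for this result.

As far as these compounds go, both groups contain carbon only, so it remains open how this position would respond to a group carrying an amine or a carboxylic acid. A much longer chain at this position also remains untested by the compounds shown here.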